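Swapping the Aryl Group at the Assay Limit

The compounds below may be only part of what the source reports. "The series", "measured", "known", "first", "only" and "open" are said of these compounds alone.

Compound 1 `COc1ccc(C(=O)/C=C/c2cccc(F)c2)c2c1C=CC(C)(C)O2`: > 10000 nM (a limit)
Compound 2 `COc1ccc(C(=O)/C=C/c2cccc([N+](=O)[O-])c2)c2c1C=CC(C)(C)O2`: 4090 nM
Compound 3 `COc1ccccc1/C=C/C(=O)c1ccc(OC)c2c1OC(C)(C)C=C2`: > 10000 nM (a limit)

All three compounds were tested in a functional assay on SW-620 cells (Homo sapiens) for antiproliferative activity, read by MTT assay, with a stated time of 24 h; on this read-out higher numbers stand for weaker inhibition and lower numbers for stronger inhibition. Compound 3 stands at the limit of > 10000 nM in this assay, at which 2 of the 3 values shown sit, so it has a limit and no number of its own. Compound 4 `COc1ccc(C(=O)/C=C/c2cccc(O)c2)c2c1C=CC(C)(C)O2` has 3-hydroxyphenyl in place of 2-methoxyphenyl on a double-bonded chain carbon bound to a double-bonded chain carbon.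

Among the compounds with values here, no measured compound carries the 3-hydroxyphenyl group, so the evidence is indirect. The closest guide is a change at the same place, an at least 2.4-fold higher number from compound 2 to compound 3 (0.38 log units; beyond the scatter), which shows that the aryl group can matter here. A second change, an at least 2.4-fold lower number from compound 1 to compound 2 (0.38 log units; beyond the scatter), shows that a different group on the aromatic carbon can bring a measurable value. The third step, a step that the two limits leave unreadable from compound 1 to compound 3, adds nothing. Compound 2 alone gives a number in this assay, at 4090 nM, and it marks the only measured level of inhibition in this small set.

The estimated step is an at least 1.4-fold lower number from compound 3 to compound 4 (0.15 log units; that floor lies within the scatter), modest and toward stronger inhibition, although a reading at the limit remains quite possible. The estimate for compound 4 is 7000 nM, with an expected range from 2500 nM to 20000 nM.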

Compound 4, half-maximal inhibitory concentration: > 10000 nM
Compound 4: no number, only a limit; the forecaster's own chance of this, stated with the estimate: 45%; middle value at least 1.4-fold (0.15 log units) from the limit.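

Compound 4 now stands with compound 1 and compound 3 at the same reading in this assay, and that reading is a limit, not a number: the limit of > 10000 nM in this assay, at which 3 of the 4 values shown sit. Hydroxy in place of nitro on the aromatic carbon gives an at least 2.4-fold higher number from compound 2 to compound 4 (0.38 log units; beyond the scatter), so a second group at this carbon separates from the nitro group by more than the scatter. Of the four aryl groups on the double-bonded chain carbon, only the 3-nitrophenyl group of compound 2 gives a measured value, while the steps from compound 3 and from compound 1 to compound 4 join two limits and cannot be read.

The compounds shown leave open how far compound 1, compound 3 and compound 4 lie from one another, and so whether the 3-hydroxyphenyl group differs at all from the 3-fluorophenyl or 2-methoxyphenyl group in this assay. They also leave open whether a measurable value is tied to the nitro group alone, or whether an amine or a carboxylic acid on the same aromatic carbon would give a number as well.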